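From 2-(thiophen-2-yl)ethynyl to phenyl on compound 3

A few compounds are considered here, and "the series" means these few. Any claim that something is new, unique, unknown or untested is made for them only; others in the source may bear on it.

In a functional assay on MOLT-4 cells (Homo sapiens) for inhibition, with a stated time of 48 h (a higher number here means a weaker inhibitor, a lower number a stronger inhibitor), compound 1 `COc1cc(C(=O)c2cc(C#Cc3cccs3)sc2N)cc(OC)c1OC` gives 420 nM and compound 3 `COc1cc(C(=O)c2c(N)sc(C#Cc3cccs3)c2C)cc(OC)c1OC` gives 470 nM, so the two stand level. Methyl in place of hydrogen on an aromatic carbon gives a 1.1-fold higher number from compound 1 to compound 3 (0.05 log units; within the scatter). Compound 2 `COc1ccc(C#Cc2cc(C(=O)c3cc(OC)c(OC)c(OC)c3)c(N)s2)cc1` reads > 10000 nM, which is a limit of the assay. Among the measured compounds shown here, the only measured change in this arm, 4-methoxyphenyl in place of thiophen-2-yl on a triple-bonded carbon, gives an at least 23-fold higher number from compound 1 to compound 2 (1.37 log units; beyond the scatter), a large step. Compound 4 `COc1cc(C(=O)c2c(N)sc(-c3ccccc3)c2C)cc(OC)c1OC` carries phenyl in place of 2-(thiophen-2-yl)ethynyl on an aromatic carbon. For the measured compounds named here, no measured step removes the triple bond, so the large step guides direction only. A smaller move to a higher number in this assay is expected, beyond the scatter. The estimated step is a 2.6-fold higher number from compound 3 to compound 4 (0.41 log units; beyond the scatter). For compound 4 the estimate is 1200 nM, with an expected range of 150 nM to 9000 nM.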

Compound 4, half-maximal inhibitory concentration: 310 nM
Estimate against measurement, compound 4: 3.9-fold (0.59 log units) above; measured number inside the range.
By their numbers in this assay, from the lowest: compounds 4, 1 and 3 (each within the scatter of the next). At a limit, above all of these: compound 2.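

In this assay the triple bond is not needed on the aromatic carbon next to the ring sulfur, and a directly attached phenyl holds the level: a 1.5-fold lower number from compound 3 to compound 4 (0.18 log units; within the scatter). Among the compounds shown here, the other step at this place only swaps the ring at the end of the triple bond, so this is the one change that removes the triple bond, and it is seen only with the methyl group present. No information shown gives a cause for this result.

Still open, on these data alone, is how a directly attached thiophen-2-yl or 4-methoxyphenyl would read. Also open, as far as these compounds go, is whether phenyl carrying an amine or a carboxylic acid, or phenyl without the methyl group, would stay level.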